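The compounds below may be only part of what the source reports. "The series", "measured", "known", "first", "only" and "open" are said of these compounds alone.

In a functional assay on HeLa cells (Homo sapiens) for cytotoxicity, read by CCK-8 assay (on this read-out higher numbers stand for weaker inhibition and lower numbers for stronger inhibition), compound 1 `COc1ccc(NC(=O)c2ncc(-c3ccccc3)o2)cc1` gives > 30000 nM, which is a limit and not a number. On these data alone, compound 2 `Cc1ccc(NC(=O)c2ncc(-c3ccccc3)o2)cc1` gives > 30000 nM, also only a limit, so its true position is unknown. Compound 3 `O=C(Nc1ccc(Cl)cc1)c1ncc(-c2ccccc2)o1` differs from it by chloro in place of methyl on an aromatic carbon, para to a large group. For the measured compounds named here, the one measured step bearing on this is a step that the two limits leave unreadable from compound 1 to compound 2, and the evidence amounts to the limit of > 30000 nM in this assay, at which 2 of the 2 values shown sit. With no measured size to carry over, no change beyond the scatter is expected in this assay, and the estimated step is a number no higher from compound 2 to compound 3 (the limit leaves the size open). Compound 3 is expected at 30000 nM, with an estimated range from 8000 nM to 60000 nM.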

Compound 3, half-maximal inhibitory concentration: > 30000 nM
Compound 3: only a limit was reported; the forecaster's own chance of this, stated with the estimate: 65%; the middle value sits exactly at the limit.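

For the compounds shown here, compound 1, compound 2 and compound 3 all give only a limit in this assay, so no step between them can be read. What the compounds shown leave open is how far their true values lie past that limit, and whether any para substituent on this phenyl ring would change them.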